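The compounds below may be only part of what the source reports. "The series", "measured", "known", "first", "only" and "open" are said of these compounds alone.

Of the compounds shown here, three sharing one core have been read in an ADME assay on ECV-304 cells (Homo sapiens) for cytotoxicity, read by MTT assay, with a stated time of 72 h (a lower number here means a stronger inhibitor, a higher number a weaker inhibitor), and none gave a number. Compound 1 (`COc1ccc(C2=C(c3cc(OC)c(OC)c(OC)c3)C(=O)CC2O[SiH2]C(C)(C)C)cc1`) gives > 100 ug/mL as a limit of the assay. Compound 2 (`COC(=O)c1cc(C2=C(c3cc(OC)c(OC)c(OC)c3)C(=O)CC2O[SiH2]C(C)(C)C)ccc1OC`) gives > 100 ug/mL as a limit as well. Compound 3 (`COc1ccc(C2=C(c3cc(OC)c(OC)c(OC)c3)C(=O)CC2O[SiH2]C(C)(C)C)cc1OC`) gives > 100 ug/mL as a limit too. Compound 3 therefore has no number of its own, and the series shows only the limit of > 100 ug/mL in this assay, at which 3 of the 3 values shown sit, so far. Compound 4 (`COc1cc(C2=C(c3ccccc3)C(O[SiH2]C(C)(C)C)CC2=O)cc(OC)c1OC`) has phenyl in place of 3,4-dimethoxyphenyl on a double-bonded ring carbon. The nearest measured change is a step that the two limits leave unreadable from compound 1 to compound 3 with methoxy in place of hydrogen on an aromatic carbon, and the other two are a step that the two limits leave unreadable from compound 1 to compound 2 and a step that the two limits leave unreadable from compound 2 to compound 3 likewise. No step beyond the scatter is therefore expected in this assay, and a further limit is likely. The expected step is a number no higher from compound 3 to compound 4 (the limit leaves the size open) on this reading. For compound 4 the estimate is 100 ug/mL with an expected range of 40 ug/mL to 250 ug/mL in this assay.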

Compound 4, half-maximal inhibitory concentration: > 100 ug/mL
Compound 4: only a limit was reported (the forecaster's own chance of this, stated with the estimate: 80%); the middle value sits exactly at the limit.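

For the compounds shown here, no step between compound 4 and compound 1, compound 2 or compound 3 can be read in this assay, since all four values are limits: the limit of > 100 ug/mL in this assay, at which 4 of the 4 values shown sit. The compounds shown leave open where each one's actual value lies.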